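From Carbamoyl to Hydrogen on the Double Bond

The source may report more compounds than this note shows. Statements on the series, on what has been measured and on what is new or still open speak of the compounds shown alone.

In a functional assay on HCT-116 cells (Homo sapiens) for cytotoxicity, read by scintillation counting and thymidine incorporation, with a stated time of 72 h (on this read-out higher numbers stand for weaker inhibition and lower numbers for stronger inhibition), compound 1 (`COc1cc(OC)cc(C(=CC(N)=O)c2ccc(OC)c(OC)c2)c1`) gives > 10000 nM, which is a limit of the assay and not a number. Its standing is therefore (the limit of > 10000 nM in this assay, at which 1 of the 3 values shown sits). Two relatives that carry no carbamoyl give true numbers: compound 2 (`CCOc1cc(C(=CC#N)c2ccc(NC)cc2)ccc1OC`) gives 55 nM, and compound 3 (`COc1cc(OC)cc(C(=C(C)C)c2ccc(OC)c(O)c2)c1`) gives 970 nM. Compound 4 (`C=C(c1cc(OC)cc(OC)c1)c1ccc(OC)c(OC)c1`) keeps the core of compound 1 and makes a single change: hydrogen in place of carbamoyl on a double-bonded chain carbon bound to a double-bonded chain carbon. For the measured compounds named here, no measured pair isolates this change, so the size of the step in this assay can only be judged indirectly. Stronger inhibition is expected because compound 3 gives 970 nM without a carbamoyl. The expected change is an at least 6.6-fold lower number from compound 1 to compound 4 (0.82 log units; beyond the scatter), towards lower numbers and well beyond the usual scatter. Compound 4 is estimated at 1500 nM, with an expected range of 250 nM to 9000 nM.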

Compound 4, half-maximal inhibitory concentration: > 10000 nM
Compound 4: no number, only a limit; the forecaster's own chance of this, stated with the estimate: 15%; at least 6.6-fold (0.82 log units) between middle value and limit.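

Compound 4, like compound 1, gives a limit of the assay and not a number: the limit of > 10000 nM in this assay, at which 2 of the 4 values shown sit. For the compounds shown here, no step from compound 1 to compound 4 can therefore be read. The compounds shown leave open whether hydrogen in place of carbamoyl changes the inhibition at all.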